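Acyl Exchange at the Ring Amide Nitrogen

A few compounds are considered here, and "the series" means these few. Any claim that something is new, unique, unknown or untested is made for them only; others in the source may bear on it.

Going by the values given here, compound 1 `O=C1COc2ccc(S(=O)(=O)N3CCC4(CC3)C3C(=O)N(c5ccccc5)C(=O)C3CN4C(=O)c3cc(C(F)(F)F)cc(C(F)(F)F)c3)cc2N1` and compound 2 `O=C1C2CN(C(=O)c3sc4ccccc4c3Cl)C3(CCNCC3)C2C(=O)N1Cc1cc(C(F)(F)F)cc(C(F)(F)F)c1` are the two measured members. In an assay on CHO cells for binding affinity to Substance-P receptor (Homo sapiens) (on this read-out lower numbers stand for stronger inhibition and higher numbers for weaker inhibition), compound 1 gives 30.9 nM, and compound 2 gives 501 nM, the higher of the two numbers by a margin beyond the scatter. Compound 3 `O=C1C2CN(C(=O)COCc3ccccc3)C3(CCNCC3)C2C(=O)N1Cc1cc(C(F)(F)F)cc(C(F)(F)F)c1` differs from compound 2 by (benzyloxy)methyl in place of 3-chloro-1-benzothiophen-2-yl on a carbonyl carbon. Among the compounds with values here, no measured pair shows this change, so its size is unknown; a step of a 1.8-fold higher number from compound 2 to compound 3 (0.25 log units; within the scatter) toward a somewhat higher number is expected in this assay. Compound 3 is estimated at 900 nM, with a range from 200 nM to 4000 nM.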

Compound 3, inhibition constant: 2290 nM
Beside the measured number, compound 3's estimate is 2.5-fold (0.41 log units) below it, within the range that was stated.
By their numbers in this assay, from the lowest: compound 1; then compound 2; then compound 3.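

On the carbonyl carbon whose other neighbour is the amide-type nitrogen in a ring, (benzyloxy)methyl in place of 3-chloro-1-benzothiophen-2-yl gives a 4.6-fold higher number from compound 2 to compound 3 (0.66 log units; beyond the scatter) in this assay. Going by these compounds alone, this is the first one-place step, and it shows that the number responds to the group at this position beyond the scatter. Nothing available bears on the reason for this step.

Whether the chlorine, the aromatic rings or the ether oxygen accounts for the step remains open. An unsubstituted 1-benzothiophen-2-yl or an aminomethyl group at this carbonyl carbon would help to separate these features.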